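The source may hold more compounds than are shown below. What is called first, only, known or untested is meant among the compounds shown, and "the series" means these compounds.

Measured compounds:
Compound 1 `Cn1cccc1C(=O)/C=C/c1ccc2c(c1)B(O)OC2`: > 100000 nM
Compound 2 `O=C(/C=C/c1ccc2c(c1)B(O)OC2)c1ccc(Cl)cc1`: 9300 nM
Compound 3 `Nc1ccc(C(=O)/C=C/c2ccc3c(c2)B(O)OC3)cc1`: 26100 nM

All three share one core and differ only in the group on the carbonyl carbon; all were run in a functional assay on HCT-116 cells (Homo sapiens) for cytotoxicity, read by MTT assay, with a stated time of 48 h; on this read-out higher numbers stand for weaker inhibition and lower numbers for stronger inhibition. For compound 1 the recorded value is a limit of the assay and not a number, (the limit of > 100000 nM in this assay, at which 1 of the 3 values shown sits). Compound 3 gives the highest of the two actual numbers; its nearest neighbour is compound 2, and the step of a 2.8-fold higher number from compound 2 to compound 3 (0.45 log units; beyond the scatter) sets the distance between them. The two steps from the limit, an at least 10-fold lower number from compound 1 to compound 2 (1.03 log units; beyond the scatter) and an at least 3.8-fold lower number from compound 1 to compound 3 (0.58 log units; beyond the scatter), show that either substituted phenyl group gives a lower number than the pyrrolyl group of compound 1.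

Compound 4 `O=C(/C=C/c1ccc2c(c1)B(O)OC2)c1cccc(F)c1` is not yet measured. Its change from compound 3 is 3-fluorophenyl in place of 4-aminophenyl on a carbonyl carbon. Among the measured compounds shown here, the step that bears on it is the amino-to-chloro pair between compound 3 and compound 2, which was modest in size; compound 4 carries a halogen on its phenyl as compound 2 does, though at a different position on the ring, and no pair reports that positional change. Compound 4 is therefore expected to give a modestly lower number than compound 3, a 2.2-fold lower number from compound 3 to compound 4 (0.34 log units; beyond the scatter), in this assay. The estimate for compound 4 is 12000 nM, with a range from 4000 nM to 40000 nM.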

Compound 4, half-maximal inhibitory concentration: 6700 nM
Beside the measured number, compound 4's estimate is 1.8-fold (0.25 log units) above it; the measured number falls inside the stated range.
By their numbers in this assay, from the lowest: compounds 4 and 2 (each within the scatter of the next); then compound 3. At a limit, above all of these: compound 1.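

In this assay, the step of a 1.4-fold lower number from compound 2 to compound 4 (0.14 log units; within the scatter) lies within the scatter, so at this place on the carbonyl carbon, 3-fluorophenyl and 4-chlorophenyl cannot be told apart, although the halogen and its place on the ring both change. Among the compounds shown here, with a 3.9-fold lower number from compound 3 to compound 4 (0.59 log units; beyond the scatter) beyond the scatter, both halogen-bearing phenyl groups now give lower numbers than 4-aminophenyl, which makes compound 3 the one phenyl member set apart from the other two, rather than one side of a single amino-to-chloro pair. The 1-methyl-1H-pyrrol-2-yl group also stays apart from this third substituted phenyl group, with an at least 14-fold lower number from compound 1 to compound 4 (1.17 log units; beyond the scatter), but compound 1 holds a limit and not a number, so this step gives only a bound: the limit of > 100000 nM in this assay, at which 1 of the 4 values shown sits.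

Since the halogen and its ring place change together in this pair, their separate contributions remain unresolved, and 3-chlorophenyl or 4-fluorophenyl would be needed to separate them. Also open, as far as these compounds go, are how unsubstituted phenyl compares with these groups and whether 3-aminophenyl would stay apart from the halogen-bearing phenyl groups as 4-aminophenyl does.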